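Ethynyl to iodo on the shared core

The compounds below may be only part of what the source reports. "The series", "measured", "known", "first", "only" and "open" are said of these compounds alone.

compound 1 `C#Cc1nc2ccccc2[se]1`: 25000 nM
compound 2 `Cn1cnc2ccccc21`: > 40000 nM, a limit and not a number

Among the compounds with values here, in a functional assay on HCT-116 cells (Homo sapiens) for cytotoxicity, with a stated time of 3 days (on this read-out higher numbers stand for weaker inhibition and lower numbers for stronger inhibition), compound 1 gives 25000 nM, the only actual number so far. Compound 3 `Ic1nc2ccccc2[se]1` carries iodo in place of ethynyl on an aromatic carbon of the core of compound 1: iodo in place of ethynyl on an aromatic carbon. Within the data shown here, no measured step between compounds bears on this change. The expected 1.3-fold lower number from compound 1 to compound 3 (0.10 log units; within the scatter) is therefore no larger than the usual scatter in this assay, with neither direction favoured. Compound 3 is estimated at 20000 nM, with an expected range of 6000 nM to 40000 nM.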

Compound 3, half-maximal inhibitory concentration: > 40000 nM
Compound 3: no number, only a limit; the forecaster's own chance of this, stated with the estimate: 25%; at least 2.0-fold (0.30 log units) between middle value and limit.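

In this assay, iodo in place of ethynyl on this aromatic carbon gives an at least 1.6-fold higher number from compound 1 to compound 3 (0.20 log units; that floor lies within the scatter), so the change shows no gain and the floor does not separate the two compounds beyond the scatter. Compound 3 gives > 40000 nM, which is a limit and not a number. The true size of the step cannot be read, because the result sits at the edge of the measurable range: the limit of > 40000 nM in this assay, at which 2 of the 3 values shown sit.

Still open, as far as these compounds go, is whether an amine, a carboxylic acid or a longer chain on this carbon would give a number at all. Within the data shown here, with compound 1 the only actual value, no trend at this position can be drawn.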